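The source may hold more compounds than are shown below. What is called first, only, known or untested is meant among the compounds shown, and "the series" means these compounds.

Measured so far:
Compound 1, `CC1(c2ccccc2)CC(=O)N(CC(=O)N2CCN(c3cccc(Cl)c3)CC2)C1=O`: 300 mg/kg in a functional assay on the whole organism (strain CD-1) with Mus musculus as the target, in the maximal electroshock model, with a stated time of 0.5 h; a lower number here means that less compound is needed, a higher number that more compound is needed for the effect
Compound 2, `CC1(c2ccccc2)CC(=O)N(CC(=O)N2CCN(c3ccccc3Cl)CC2)C1=O`: "not active" (no number reported) in this assay

Compound 2 stands without a number: in this assay compound 2 is reported only as "not active" (no number reported), so its place against compound 1 cannot be set on a scale. Among the measured compounds shown here, compound 1 in this assay gives 300 mg/kg, the only number so far.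

Compound 3, `CC1(c2ccccc2)CC(=O)N(CC(=O)N2CCN(c3ccc(F)cc3)CC2)C1=O`, is not yet measured. It differs from compound 2 in one place: 4-fluorophenyl in place of 2-chlorophenyl on an amine nitrogen in a ring. For the measured compounds named here, no step between two measured compounds is available, and compound 2 carries no number, so the size of the step from compound 2 to compound 3 in this assay cannot be expected as a figure; the only open question is whether compound 3 returns a number at all. With compound 1 as the sole numeric anchor, compound 3 is expected in this assay to give about 300 mg/kg, within a range of 100 mg/kg to 600 mg/kg.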

Compound 3, minimum effective dose: 100 mg/kg
Estimate against measurement, compound 3: 3.0-fold (0.48 log units) above; measured number inside the range.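

In this assay, the aryl group on the amine nitrogen in a ring now gives a second number: 4-fluorophenyl in place of 3-chlorophenyl gives a 3.0-fold lower number from compound 1 to compound 3 (0.48 log units; beyond the scatter), a modest step beyond the scatter. The step from compound 2 to compound 3 cannot be read as a size, but compound 3 gives 100 mg/kg where compound 2 is reported as "not active", so the outcome at this place differs among the three aryl groups. No accompanying data bear on the origin of these differences.

Each comparison changes both the halogen and its printed ring position, so their contributions cannot be separated. Readings for 4-chlorophenyl, 3-fluorophenyl and unsubstituted phenyl at this place would be needed to separate them, and whether any aryl group here reaches a lower number than compound 3 remains open.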